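The source may hold more compounds than are shown below. What is called first, only, known or untested is meant among the compounds shown, and "the series" means these compounds.

Measured so far in a functional assay on the whole organism (strain Swiss) with Mus musculus as the target, in the maximal electroshock model, with a stated time of 1 h, at a dose of 300 mg/kg by the intraperitoneal route; a higher number here means a stronger effect of the compound at the dose given, a lower number a weaker effect:
Compound 1, `CCC(C(=O)N1CCN(c2cccc(OC)c2)CC1)N1C(=O)CCC1=O`, gives 0%.
Compound 2, `CCC(C(=O)N1CCN(c2ccc(F)cc2)CC1)N1C(=O)CCC1=O`, gives 25%.
Compound 3, `CCC(C(=O)N1CCN(c2cccc(C)c2)CC1)N1C(=O)CCC1=O`, gives 75%.

Compound 3 stands highest of the three. Compound 2 comes nearest to it, a number 50 percentage points higher from compound 2 to compound 3 (beyond the scatter), and compound 1 lies furthest, a number 75 percentage points higher from compound 1 to compound 3 (beyond the scatter). Compound 4, `CCC(C(=O)N1CCN(c2ccc(Cl)cc2)CC1)N1C(=O)CCC1=O`, has not been measured. It differs from compound 3 in one place: 4-chlorophenyl in place of 3-methylphenyl on an amine nitrogen in a ring.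

Of the groups measured here, 4-fluorophenyl is the one most like 4-chlorophenyl. Among the compounds with values here, the step that bears on this change is therefore the one from compound 2 to compound 3; that step was a number 50 percentage points higher from compound 2 to compound 3 (beyond the scatter). Going from compound 3 to compound 4 largely reverses it, so a downward step is expected in this assay, of about a number 35 percentage points lower from compound 3 to compound 4 (beyond the scatter). Since no 4-chlorophenyl has been measured here, the range is wide. Compound 4 is estimated at 40%, expected to lie between 5% and 80%.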

Compound 4, a percentage reported as activity, at one dose (the size of the read-out at that dose, not a potency): 25%
Compound 4: the middle estimate sits 15 percentage points above what was measured; measured number inside the range.
By their numbers in this assay, from the lowest: compound 1; then compounds 2 and 4 (each within the scatter of the next); then compound 3.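

In this assay, the change from 3-methylphenyl to 4-chlorophenyl on the amine nitrogen in a ring gives a number 50 percentage points lower from compound 3 to compound 4 (beyond the scatter), so a second group with a halogen also falls well short of 3-methylphenyl at this site. Chloro in place of fluoro on the same aromatic carbon gives no change at the digits printed from compound 2 to compound 4 (within the scatter), so this assay does not separate these two halogens at the dose given. The 4-chlorophenyl group still keeps an advantage over 3-methoxyphenyl, with a number 25 percentage points higher from compound 1 to compound 4 (beyond the scatter), which matches the earlier rise seen with 4-fluorophenyl.

The compounds shown do not settle whether the high value of compound 3 depends on the methyl group itself or on where it sits on the ring, and 4-methylphenyl and 3-chlorophenyl, the groups that could separate these two readings, are not among them. Nothing available here explains any of these differences.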